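Moving from 2-methylphenyl to 4-(trifluoromethyl)phenyl on the carbonyl

The compounds below may be only part of what the source reports. "The series", "measured", "known", "first", "only" and "open" are said of these compounds alone.

Compound 1 `Cc1ccccc1C(=O)N(C(=S)OCCN1C(=O)c2ccccc2C1=O)c1ccc(Cl)cc1` was examined in an ADME assay on MT4 cells (Homo sapiens) for cytotoxicity, read by MTT assay (on this read-out higher numbers stand for lower toxicity in this test and lower numbers for higher toxicity in this test), where compound 1 gives 21000 nM, the higher of the two numbers recorded. Compound 2 `O=C1c2ccccc2C(=O)N1CCOC(=S)N(C(=O)c1cccc([N+](=O)[O-])c1)c1ccc(Cl)cc1` sits close by: in this assay compound 2 gives 18000 nM, and the step of a 1.2-fold lower number from compound 1 to compound 2 (0.07 log units; within the scatter) stays within the scatter. Compound 3 `Cc1ccc(C(=O)N(C(=S)OCCN2C(=O)c3ccccc3C2=O)c2ccc(Cl)cc2)cc1` reached only a limit of the assay, as in this assay compound 3 gives > 100000 nM (the limit of > 100000 nM in this assay, at which 1 of the 3 values shown sits). Compound 4 `O=C1c2ccccc2C(=O)N1CCOC(=S)N(C(=O)c1ccc(C(F)(F)F)cc1)c1ccc(Cl)cc1` has not yet been measured; it differs from compound 1 by 4-(trifluoromethyl)phenyl in place of 2-methylphenyl on a carbonyl carbon. The step that bears on this is an at least 4.7-fold higher number from compound 1 to compound 3 (0.67 log units; beyond the scatter), where 4-methylphenyl likewise replaced 2-methylphenyl, and an at least 5.5-fold higher number from compound 2 to compound 3 (0.74 log units; beyond the scatter) points the same way. The account therefore expects a higher number for compound 4, a step of a 2.9-fold higher number from compound 1 to compound 4 (0.46 log units; beyond the scatter). Compound 4 is estimated at 60000 nM, within a range from 20000 nM to 150000 nM.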

Compound 4, half-maximal cytotoxic concentration: 10000 nM
Estimate against measurement, compound 4: 6.0-fold (0.78 log units) above; the measured number lies below the stated range.
By their numbers in this assay, from the lowest: compounds 4, 2 and 1 (each within the scatter of the next, the first and the last beyond it). At a limit, above all of these: compound 3.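

Compound 4 shows that not every replacement of 2-methylphenyl on this carbonyl carbon raises the number: this one gives a 2.1-fold lower number from compound 1 to compound 4 (0.32 log units; beyond the scatter) in this assay. Trifluoromethyl in place of methyl on the aromatic carbon gives an at least 10-fold lower number from compound 3 to compound 4 (1.00 log units; beyond the scatter) and so reverses what compound 3 suggested, while a 1.8-fold lower number from compound 2 to compound 4 (0.26 log units; within the scatter) leaves compound 4 and compound 2 apart by no more than the scatter. The number for compound 3 is a limit of the assay: the limit of > 100000 nM in this assay, at which 1 of the 4 values shown sits.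

Going by these compounds, it remains open whether the higher number of compound 3 is particular to methyl. An amine or a carboxylic acid on the phenyl ring, or a longer chain in place of methyl, could test this.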